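The compounds below may be only part of what the source reports. "The series", "measured", "known", "first", "only" and "open" are said of these compounds alone.

Measured in a functional assay on HL-60 cells (Homo sapiens) for antiproliferative activity, read by MTT assay, with a stated time of 72 h; on this read-out lower numbers stand for stronger inhibition and higher numbers for weaker inhibition:
- Compound 1 `CCOc1ccc(-c2ncnn2-c2cc(OC)c(OC)c(OC)c2)cc1Cl`: 3 nM
- Compound 2 `COc1cc(-n2ncnc2-c2ccc(Cl)c(Cl)c2)cc(OC)c1OC`: > 10000 nM

Compound 2 gives only a limit of the assay, > 10000 nM. Compound 3 `COc1cc(-n2ncnc2-c2cccc(Cl)c2)cc(OC)c1OC` differs from it by hydrogen in place of chloro on an aromatic carbon, 3,4-dichlorophenyl to 3-chlorophenyl (hydrogen in place of chloro on an aromatic carbon). Going by the values given here, the one measured step that bears on this is large: an at least 3300-fold higher number from compound 1 to compound 2 (3.52 log units; beyond the scatter), with chloro in place of ethoxy on that same carbon. Compound 3 has no ethoxy either, so it is not expected to approach compound 1 at 3 nM. Only a modest move to a lower number, or none beyond the scatter, is expected. The estimated step is an at least 1.6-fold lower number from compound 2 to compound 3 (0.22 log units; that floor lies within the scatter). For compound 3 the expected value is 6000 nM, with an estimated range of 800 nM to 10000 nM.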

Compound 3, half-maximal inhibitory concentration: > 10000 nM
Compound 3: a limit, no number (the forecaster's own chance of this, stated with the estimate: 60%); at least 1.6-fold (0.22 log units) between middle value and limit.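

In this assay compound 3 gives only a limit of the assay, > 10000 nM. Hydrogen in place of ethoxy on this aromatic carbon gives an at least 3300-fold higher number from compound 1 to compound 3 (3.52 log units; beyond the scatter), so neither chloro nor hydrogen at this carbon brings back a readable value. The step between compound 2 and compound 3 cannot be read, as both are limits: the limit of > 10000 nM in this assay, at which 2 of the 3 values shown sit.

Going by these compounds, whether a shorter or longer group on this carbon, such as hydroxyl or propoxy, keeps the activity of compound 1 stays open.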